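The source may report more compounds than this note shows. Statements on the series, on what has been measured and on what is new or still open speak of the compounds shown alone.

Three measured compounds share one core. Compound 1 `Fc1cccc(F)c1Cn1c(-c2c(F)cccc2F)nc2ccncc21` in an ADME assay on MDBK cells (Bos taurus) for cytotoxicity (on this read-out higher numbers stand for lower toxicity in this test and lower numbers for higher toxicity in this test), gives 99000 nM. Compound 3 `FC(F)(F)c1cccc(Cn2ccc3nc(-c4ccccc4)nc-3c2)c1` in this assay gives 98000 nM. Compound 2 `Fc1cccc(Cn2ccc3nc(-c4ccccc4)nc-3c2)c1` in this assay reaches only the limit of the assay, > 100000 nM, so its true value is not known as a number. That limit is recorded in the limit of > 100000 nM in this assay, at which 1 of the 3 values shown sits. Among the compounds with values here, the only step measured between two compounds that differ in one place runs an at least 1.0-fold lower number from compound 2 to compound 3 (0.00 log units; that floor lies within the scatter), and with compound 2 at a limit this step tells little about the size of any change.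

Compound 4 `Clc1ccc(Cn2ccc3nc(-c4ccccc4)nc-3c2)cc1Cl` differs from compound 2 by 3,4-dichlorophenyl in place of 3-fluorophenyl on a saturated chain carbon bound to an aromatic nitrogen. Within the data shown here, no measured step covers this kind of change, and the one step that exists, from a fluoro to a trifluoromethyl group, stayed within the scatter. The estimate for compound 4 in this assay is therefore 80000 nM, within a range from 30000 nM to 100000 nM, which means an expected step of an at least 1.2-fold lower number from compound 2 to compound 4 (0.09 log units; that floor lies within the scatter).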

Compound 4, half-maximal cytotoxic concentration: 71000 nM
Compound 4: the middle estimate sits 1.1-fold (0.05 log units) above what was measured; low and high end bracket the measured number.
By their numbers in this assay, from the lowest: compounds 4, 3 and 1 (each within the scatter of the next). At a limit, above all of these: compound 2.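

Putting 3,4-dichlorophenyl in place of 3-fluorophenyl on a saturated chain carbon bound to an aromatic nitrogen gives an at least 1.4-fold lower number from compound 2 to compound 4 (0.14 log units; that floor lies within the scatter) in this assay. This adds a second kind of change at this position, with two chlorine atoms on the ring, and its floor, like that of the earlier trifluoromethyl step, stays within the scatter. The true size of the step is still unknown, since compound 2 sits at a limit and not at a number: the limit of > 100000 nM in this assay, at which 1 of the 4 values shown sits.

The compounds shown leave open whether this position would respond differently to a ring carrying an amine or a carboxylic acid. They also leave open whether a longer chain between the ring and the aromatic nitrogen would move the number in this assay beyond the scatter.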